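A Methoxy Group Added to a Phenyl Ring

The compounds below may be only part of what the source reports. "The series", "measured", "known", "first", "only" and "open" are said of these compounds alone.

Three compounds have been measured in a functional assay on Jurkat cells (Homo sapiens) for cytotoxicity, read by MTT assay, with a stated time of 24 h; a higher number here means that more compound is needed for the effect, a lower number that less compound is needed:

compound 1, `CCOC(=O)c1cc([Se]c2ccc3cc(OC)ccc3c2)c2cc(OC)ccc2n1`, 31300 nM
compound 2, `CCOC(=O)c1cc([Se]c2ccccc2)c2cc(OC)ccc2n1`, 102000 nM
compound 3, `CCOC(=O)c1cc([Se]c2ccc3ccccc3c2)c2cc(OC)ccc2n1`, 50700 nM

All three share the same core and differ only in the ring attached through selenium. Compound 3 and compound 1 differ by methoxy in place of hydrogen on an aromatic carbon, and the step of a 1.6-fold lower number from compound 3 to compound 1 (0.21 log units; within the scatter) is small. Compound 2 gives the highest number of the three; the difference between its core and that of compound 3 is not broken down here.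

Compound 4, `CCOC(=O)c1cc([Se]c2ccc(OC)cc2)c2cc(OC)ccc2n1`, has not yet been measured. It differs from compound 2 by methoxy in place of hydrogen on an aromatic carbon. In compound 1 the methoxy sits on a ring that is part of a fused or bridged system of two rings, meta to a fused ring and para to a fused ring, whereas in compound 4 it sits para to a large group; so this is the same kind of change, not the same change. Because the step of a 1.6-fold lower number from compound 3 to compound 1 (0.21 log units; within the scatter) was within scatter, the expected step of a 1.6-fold lower number from compound 2 to compound 4 (0.20 log units; within the scatter) is estimated to be of similar size. Compound 4 is therefore expected to give about 65000 nM, with an estimated range from 30000 nM to 150000 nM.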

Compound 4, half-maximal effective concentration: 82500 nM
Compound 4: the middle estimate sits 1.3-fold (0.10 log units) below what was measured; low and high end bracket the measured number.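

In this assay, putting methoxy in place of hydrogen on the ring attached through selenium, para to a large group, gives a 1.2-fold lower number from compound 2 to compound 4 (0.09 log units; within the scatter). Set beside the earlier case, the change looks alike on the two cores, and the two steps cannot be told apart: the same change on two cores in this assay, a 1.6-fold lower number (0.21 log units; within the scatter) from compound 3 to compound 1 and a 1.2-fold lower number (0.09 log units; within the scatter) from compound 2 to compound 4, 1.3-fold (0.12 log units) apart, within the scatter of two such steps. This agreement is only between two small steps, each within the scatter, and it does not show that methoxy has a real effect on this read-out that travels from one core to another; the methoxy also stands in a different place in each pair, so this is the same kind of change and not the identical one.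

The compounds shown leave open whether a different group on the ring attached through selenium, such as an amine or a carboxylic acid, would give a step beyond the scatter. They also leave open what happens when the ester on the shared core is replaced by an amide or a carboxylic acid.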